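From 1-acetylpyrrolidin-3-yl to 1-methylpiperidin-4-yl

The compounds below may be only part of what the source reports. "The series", "measured", "known", "first", "only" and "open" are said of these compounds alone.

- compound 1 `CC(=O)N1CCC(c2ccc(Nc3nc(N)n(-c4ccccn4)n3)cc2)C1`: 1.42 h
- compound 2 `CN1CCC(c2cccc(Nc3nc(N)n(-c4ccccn4)n3)c2)CC1`: 2.48 h

In an in vivo ADME assay on the whole organism for metabolic stability, with Rattus norvegicus as the target (on this read-out lower numbers stand for a shorter-lived compound and higher numbers for a longer-lived compound), compound 1 gives 1.42 h, which lies within the scatter of compound 2 at 2.48 h. Compound 3 `CN1CCC(c2ccc(Nc3nc(N)n(-c4ccccn4)n3)cc2)CC1` has 1-methylpiperidin-4-yl in place of 1-acetylpyrrolidin-3-yl on an aromatic carbon. Compound 2 also carries 1-methylpiperidin-4-yl, and its 2.48 h is the main basis for the expectation here. A modest upward step is expected in this assay, a 1.7-fold higher number from compound 1 to compound 3 (0.23 log units; within the scatter), and it may not clear the scatter. Compound 3 is estimated at 2.4 h, with an expected range of 1.2 h to 4.8 h.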

Compound 3, half-life: 2.45 h
Estimate against measurement, compound 3: 1.0-fold (0.01 log units) below; low and high end bracket the measured number.
By their numbers in this assay, from the lowest: compounds 1, 3 and 2 (each within the scatter of the next).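

In this assay, going by these compounds alone, the exchange of 1-acetylpyrrolidin-3-yl for 1-methylpiperidin-4-yl on an aromatic carbon, para to a large group, gives a 1.7-fold higher number from compound 1 to compound 3 (0.24 log units; within the scatter) and is the first direct reading of this change at this position. On this read-out the two groups are therefore not told apart. Nothing at hand explains this result.

From the compounds shown here alone, because ring size and the nitrogen substituent change together, the pair cannot separate them. 1-Acetylpiperidin-4-yl or 1-methylpyrrolidin-3-yl at the same place would address that, while a morpholine remains open as well.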